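This account rests on a few compounds, and the source may have more. Where it says the series, first, only, none or still open, it means among the compounds named here.

Three measured compounds share a common core, a carbon with a double bond to nitrogen that carries two amide-type nitrogens, and differ in the acyl groups and in the group on selenium. Compound 1 is `C[Se]/C(=N\C(=O)c1ccco1)NC(=O)c1ccco1`, compound 2 is `O=C(/N=C(/NC(=O)c1ccno1)[Se]Cc1ccccc1)c1ccno1` and compound 3 is `O=C(/N=C(/NC(=O)c1cc(-c2ccccc2)nc2ccccc12)[Se]Cc1ccccc1)c1cc(-c2ccccc2)nc2ccccc12`. In a functional assay on HT-29 cells (Homo sapiens) for cytotoxicity, read by MTT assay, with a stated time of 72 h (a lower number here means that less compound is tolerated, a higher number that more compound is tolerated), compound 1 gives only a limit, > 100000 nM. In this assay compound 2 likewise reaches only a limit, > 100000 nM. Compound 3 stands at the same place: in this assay compound 3 gives a limit as well, > 100000 nM, so no number places it relative to the other two, and the picture is summed up by the limit of > 100000 nM in this assay, at which 3 of the 3 values shown sit. The unmeasured compound 4 is `CS/C(=N\C(=O)c1cc(-c2ccccc2)nc2ccccc12)NC(=O)c1cc(-c2ccccc2)nc2ccccc12`. Going from compound 3 to compound 4, (a group of 2 heavy atoms (1 carbon, 1 sulfur; no ring) in place of a group of 8 heavy atoms (7 carbon, 1 selenium; one six-membered aromatic ring of carbon only), on a carbon with a double bond to nitrogen). Among the compounds with values here, no step between measured compounds with a number exists here, so the size of this change cannot be read from a measured pair. Since compound 3 sits at > 100000 nM, compound 4 is expected to remain at or near the same limit in this assay, with a step that the limit leaves unreadable from compound 3 to compound 4 expected. Compound 4 is thus estimated at 150000 nM, within a range from 50000 nM to 500000 nM.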

Compound 4, concentration lethal to 50% of the cells: > 100000 nM
Compound 4 was reported as a limit (the forecaster's own chance of this, stated with the estimate: 80%); the middle value is on the limit's open side.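

In this assay compound 3 and compound 4 both give only limits, so no new step can be read between them: the limit of > 100000 nM in this assay, at which 4 of the 4 values shown sit. The compounds shown leave open what lethal concentration any of them has, and whether the group on the carbon with a double bond to nitrogen changes it at all.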